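Difluorophenyl ketone on a trimethoxyphenyl pyrazole core

The source may report more compounds than this note shows. Statements on the series, on what has been measured and on what is new or still open speak of the compounds shown alone.

Compounds measured in a functional assay on SN12C cells (Homo sapiens) for cytotoxicity, read by sulforhodamine B assay, with a stated time of 48 h, tested at 100 uM; a lower number here means a stronger effect, a higher number a weaker effect of the compound at the concentration tested:
compound 1 `COc1ccc(-c2cc(/C=C/C(=O)c3ccc(N)cc3)[nH]n2)cc1` gives -78%
compound 2 `COc1cc(-c2cc(/C=C/C(=O)c3ccc(N)cc3)[nH]n2)cc(OC)c1OC` gives -86%
compound 3 `COc1cc(-c2cc(/C=C/C(=O)c3ccc(Cl)c(Cl)c3)[nH]n2)cc(OC)c1OC` gives 11%

Compound 2 has the lowest of the three numbers in this assay. Compound 1 sits nearest to it, within the scatter, so the two cannot be ranked. Compound 3 lies furthest away, with a number 97 percentage points higher from compound 2 to compound 3 (beyond the scatter), a large step that follows from putting 3,4-dichlorophenyl in place of 4-aminophenyl on the carbonyl carbon.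

Compound 4 `COc1cc(-c2cc(/C=C/C(=O)c3ccc(F)c(F)c3)[nH]n2)cc(OC)c1OC` has not yet been measured in this assay. It differs from compound 2 as follows: 3,4-difluorophenyl in place of 4-aminophenyl on a carbonyl carbon. Among the compounds with values here, the one measured step that bears on this change is the one from compound 2 to compound 3, where a dihalogenated phenyl likewise replaced the 4-aminophenyl on the carbonyl carbon, and that step was large and upward. Within the data shown here, a step of comparable direction and roughly comparable size is therefore expected for compound 4, though with wide uncertainty since only one such step exists. Compound 4 is estimated to give 0%, in the range -45% to 30%, corresponding to an expected a number 86 percentage points higher from compound 2 to compound 4 (beyond the scatter).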

Compound 4, a percentage reported as activity, at one concentration (the size of the read-out at that concentration, not a potency): -22%
Compound 4: the middle estimate sits 22 percentage points above what was measured; the range from low to high includes it.
By their numbers in this assay, from the lowest: compounds 2 and 1 (each within the scatter of the next); then compound 4; then compound 3.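

In this assay the place on the carbonyl carbon now holds two dihalogenated phenyl groups, and they do not behave alike: replacing 4-aminophenyl with 3,4-difluorophenyl gives a large rise (a number 64 percentage points higher from compound 2 to compound 4 (beyond the scatter)), while replacing 3,4-dichlorophenyl with 3,4-difluorophenyl gives a large fall (a number 33 percentage points lower from compound 3 to compound 4 (beyond the scatter)). The size of the change on leaving 4-aminophenyl therefore depends on which halogen enters, and compound 4 matches neither compound 2 nor compound 3. Nothing available here accounts for the gap between the two halogens.

Going by these compounds, whether a 4-hydroxyphenyl or 4-dimethylaminophenyl group on the carbonyl carbon would stay close to compound 2 or move toward compound 4 remains open. So does whether 3,4-difluorophenyl would produce a similar step on the core of compound 1.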